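Oxan-4-yl on the Aromatic Nitrogen of Compound 2

The source may report more compounds than this note shows. Statements on the series, on what has been measured and on what is new or still open speak of the compounds shown alone.

In a functional assay on MDA-MB-231 cells (Homo sapiens) for inhibition, read by MTT assay, with a stated time of 5 days (a lower number here means a stronger inhibitor, a higher number a weaker inhibitor), compound 1 (`Cc1cc(Nc2nc(NCc3cccc(Cl)c3)nc3[nH]ncc23)n[nH]1`) gives 6860 nM, compound 2 (`Cc1cc(Nc2nc(NCc3ccc(Cl)cc3)nc3[nH]ncc23)n[nH]1`) gives 7500 nM and compound 3 (`COc1ccc(CNc2nc(Nc3cc(C)[nH]n3)c3cn[nH]c3n2)cc1`) gives 1320 nM. Compound 2 thus shares the high end of the three numbers with compound 1, as a 1.1-fold higher number from compound 1 to compound 2 (0.04 log units; within the scatter) shows, while a 5.7-fold lower number from compound 2 to compound 3 (0.75 log units; beyond the scatter) separates it from compound 3. Compound 4 (`Cc1cc(Nc2nc(NCc3ccc(Cl)cc3)nc3c2cnn3C2CCOCC2)n[nH]1`) carries oxan-4-yl in place of hydrogen on an aromatic nitrogen. The measured steps, including a 5.2-fold lower number from compound 1 to compound 3 (0.72 log units; beyond the scatter), change only the aromatic group on the saturated chain carbon, so none of them tests this nitrogen and the data give no direction. The expected change is a 1.5-fold lower number from compound 2 to compound 4 (0.18 log units; within the scatter), with no shift beyond the scatter anticipated. For compound 4, the estimated value is 5000 nM, with an expected range of 1500 nM to 17000 nM.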

Compound 4, half-maximal inhibitory concentration: 9420 nM
Beside the measured number, compound 4's estimate is 1.9-fold (0.28 log units) below it, within the range that was stated.
By their numbers in this assay, from the lowest: compound 3; then compounds 1, 2 and 4 (each within the scatter of the next).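

Compound 4 is the only compound shown with a group on the aromatic nitrogen, and in this assay oxan-4-yl in place of hydrogen gives a 1.3-fold higher number from compound 2 to compound 4 (0.10 log units; within the scatter) and so no change beyond the scatter. In this pair, the aromatic nitrogen therefore carries a six-membered non-aromatic ring without losing the activity that compound 2 shows. No measured evidence accounts for this result. 

Going by these compounds, it remains open whether oxan-4-yl on this nitrogen would behave alike with the 4-methoxyphenyl of compound 3. On these data alone, whether a methyl group or a chain ending in an amine would be tolerated there also remains open.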